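Swapping a Fluorophenyl for a Bromophenyl Group

The source may report more compounds than this note shows. Statements on the series, on what has been measured and on what is new or still open speak of the compounds shown alone.

Among the measured compounds shown here, compound 2 `CCN(Cc1ccc(F)cc1)c1cccc(C(=O)N2CCc3ccc(OS(N)(=O)=O)cc3C2)c1` is one of two compounds measured in an assay on HEK293 cells for inhibition of Steryl-sulfatase (Homo sapiens), tested at 1 uM; on this read-out higher numbers stand for a stronger effect at the one concentration tested and lower numbers for a weaker effect. Compound 2 gives 66.5%, the lower of the two numbers. Compound 1 `CC(C)CCN(CCC(C)C)c1ccc(C(=O)N2CCc3ccc(OS(N)(=O)=O)cc3C2)cc1` gives 90.8%, and that gap lies beyond the usual scatter. Compound 3 `CCN(Cc1cccc(Br)c1)c1cccc(C(=O)N2CCc3ccc(OS(N)(=O)=O)cc3C2)c1` has not yet been measured. It differs from compound 2 in one place: 3-bromophenyl in place of 4-fluorophenyl on a saturated chain carbon bound to a nitrogen on an aromatic ring. For the measured compounds named here, no measured pair shows this change, so its size is unknown; the expected effect in this assay is none beyond the scatter. Compound 3 is therefore estimated at 68%, within a range from 50% to 85%. This means an expected step of a number 1.5 percentage points higher from compound 2 to compound 3 (within the scatter).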

Compound 3, a percentage reported as inhibition, at one concentration (the size of the read-out at that concentration, not a potency): 24.9%
Compound 3: middle estimate off by 43.1 percentage points, on the high side, outside the stated range (below it).
By their numbers in this assay, from the lowest: compound 3; then compound 2; then compound 1.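

In this assay, 3-bromophenyl in place of 4-fluorophenyl gives a number 41.6 percentage points lower from compound 2 to compound 3 (beyond the scatter) and so shows that this position on the saturated chain carbon is sensitive to the change. The two groups have the same count of heavy atoms and the same kind of ring, yet the read-out still shifts by a large step. No measurement at hand explains this drop.

Going by these compounds, both the halogen and its place on the ring change in this one step, so their separate shares remain open. A 4-bromophenyl or a 3-fluorophenyl group at the same position would separate them.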